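A few compounds are considered here, and "the series" means these few. Any claim that something is new, unique, unknown or untested is made for them only; others in the source may bear on it.

Compound 1 `CC(=O)N1N=C(c2ccc(C)cc2)CC1c1cn(-c2ccccc2)nc1-c1ccc(Cl)c(Cl)c1` and compound 2 `CC(=O)N1N=C(c2ccc(F)cc2)CC1c1cn(-c2ccccc2)nc1-c1ccc(Cl)c(Cl)c1` share one core and differ at a single aromatic carbon. In a functional assay on the whole organism (strain Wistar) for inhibition, with Rattus norvegicus as the target, read by paw edema, with stated times of 30 min and 120 min, at a dose of 50 mg/kg by the oral route (a higher number here means more inhibition at the dose given (going by the name of the read-out), a lower number less inhibition), compound 1 gives 70.3%. In this assay compound 2 gives 72.7%; the step from one to the other, a number 2.4 percentage points higher from compound 1 to compound 2 (within the scatter), lies within the scatter, so the two numbers cannot be told apart. Compound 3 `CC(=O)N1N=C(c2ccc(Cl)cc2)CC1c1cn(-c2ccccc2)nc1-c1ccc(Cl)c(Cl)c1` is the next member of the set. The change from compound 2 to compound 3 is chloro in place of fluoro on an aromatic carbon. For the measured compounds named here, the only measured step that speaks to this change is the swap at the same place going from compound 1 to compound 2, which was a number 2.4 percentage points higher from compound 1 to compound 2 (within the scatter) and stayed within the scatter. A second exchange of one small group at that place is therefore expected to leave the number in this assay essentially where it is. Compound 3 is expected to give 71% in this assay, within a range from 58% to 82%. This amounts to an expected step of a number 1.7 percentage points lower from compound 2 to compound 3 (within the scatter), nothing beyond the scatter.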

Compound 3, a percentage reported as inhibition, in the whole organism at one dose (the size of the read-out at that dose, not a potency): 66.4%
Beside the measured number, compound 3's estimate is 4.6 percentage points above it, within the range that was stated.
By their numbers in this assay, from the lowest: compounds 3, 1 and 2 (each within the scatter of the next).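

The exchange of 4-fluorophenyl for 4-chlorophenyl gives a number 6.3 percentage points lower from compound 2 to compound 3 (within the scatter) in this assay, and chloro in place of methyl gives a number 3.9 percentage points lower from compound 1 to compound 3 (within the scatter). Methyl, fluoro and chloro at this aromatic carbon therefore cannot be told apart in this assay, so this position now has three small groups that all give matching results, where the earlier pair offered only one comparison. No measurement at hand speaks to what lies behind this sameness.

The compounds shown leave open whether this level of inhibition would hold with a quite different group at this place, such as an amine, a carboxylic acid or a longer chain. They also leave open what changes elsewhere on the shared core would do.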